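The source may hold more compounds than are shown below. What is called first, only, known or untested is meant among the compounds shown, and "the series" means these compounds.

Three compounds have so far been measured in a functional assay on SKHep cells (Homo sapiens) for antiproliferative activity, read by MTT assay, with a stated time of 12 h; a lower number here means a stronger inhibitor, a higher number a weaker inhibitor:

Compound 1, `COc1cc(OC)c2c(=O)cc(/C=C/c3ccc([N+](=O)[O-])cc3)oc2c1`: 22000 nM
Compound 2, `COc1cc(OC)c2c(=O)cc(/C=C/c3ccc(OCC4CC4)cc3)oc2c1`: 22100 nM
Compound 3, `COc1ccc(/C=C/c2cc(=O)c3c(OC)cc(OC)cc3o2)cc1`: > 40000 nM

Compound 3 stands apart from the other two in that its result in this assay is only a limit of the assay, > 40000 nM, not a number. The two steps leading to it, an at least 1.8-fold higher number from compound 1 to compound 3 (0.25 log units; that floor lies within the scatter) and an at least 1.8-fold higher number from compound 2 to compound 3 (0.25 log units; that floor lies within the scatter), each have a floor that lies within the scatter, so nothing beyond the scatter is established for either. The step of a 1.0-fold higher number from compound 1 to compound 2 (0.00 log units; within the scatter) is likewise within the scatter. The unmeasured compound 4, `COc1cc(OC)c2c(=O)cc(/C=C/c3ccc(Br)cc3)oc2c1`, differs from compound 3 by bromo in place of methoxy on an aromatic carbon. For the measured compounds named here, no measured step exchanges a methoxy for a bromo, so the only guidance is that all three measured compounds, whatever group sits on that aromatic carbon, give weak numbers or a limit in this assay. Compound 4 is therefore expected to fall in the same region, with an estimated step of an at least 1.6-fold lower number from compound 3 to compound 4 (0.20 log units; that floor lies within the scatter). The estimate for compound 4 is 25000 nM, in a range from 9000 nM to 70000 nM.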

Compound 4, half-maximal inhibitory concentration: > 40000 nM
Compound 4: no number, only a limit; the forecaster's own chance of this, stated with the estimate: 40%; middle value at least 1.6-fold (0.20 log units) away from the limit.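

In this assay compound 4 gives > 40000 nM, which is a limit of the assay and not a number, so the bromo group, like the methoxy group, yields no number at this place para to a large group. Against the nitro and cyclopropylmethoxy groups, the result reads as an at least 1.8-fold higher number from compound 1 to compound 4 (0.25 log units; that floor lies within the scatter) and an at least 1.8-fold higher number from compound 2 to compound 4 (0.25 log units; that floor lies within the scatter), so the change to bromo establishes nothing beyond the scatter against either group. The step between the methoxy and bromo compounds cannot be read, because both rest on the same limit: the limit of > 40000 nM in this assay, at which 2 of the 4 values shown sit.

On these data alone, whether any group on this aromatic carbon can move the number beyond the scatter stays open. So does what an amine or a carboxylic acid would give there, and how far compound 3 and compound 4 actually lie from each other.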